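The source may report more compounds than this note shows. Statements on the series, on what has been measured and on what is new or still open speak of the compounds shown alone.

In a functional assay on DU-145 cells (Homo sapiens) for antiproliferative activity, read by sulforhodamine B assay, with a stated time of 3 days (on this read-out higher numbers stand for weaker inhibition of growth and lower numbers for stronger inhibition of growth), compound 1 (`COc1ccc(N2CCN(C)CC2)cc1Nc1ncc(F)c(Nc2ccc(F)cc2)n1`) gives 910 nM and compound 2 (`O=C(Nc1cccc(Nc2ncc(F)c(Nc3ccc(F)cc3)n2)c1)c1cnccn1`) gives 26400 nM while compound 3 (`O=C(Nc1cccc(Nc2ncc(F)c(Nc3ccc(F)cc3)n2)c1)c1cccc([N+](=O)[O-])c1`) gives 12600 nM as the second highest of the three numbers. Compound 3 therefore lies close to compound 2 and far from compound 1. Compound 4 (`CN(C)c1ccc(C(=O)Nc2cccc(Nc3ncc(F)c(Nc4ccc(F)cc4)n3)c2)cc1`), not yet measured, carries 4-(dimethylamino)phenyl in place of 3-nitrophenyl on a carbonyl carbon. Within the data shown here, the one measured step at this place is a 2.1-fold lower number from compound 2 to compound 3 (0.32 log units; beyond the scatter) when 3-nitrophenyl replaces pyrazin-2-yl, and it is modest. Among the measured compounds shown here, no measured compound pairs 4-(dimethylamino)phenyl with another group here, so that single step hints at the size of a change at this place but sets no direction for the new one. No step beyond the usual scatter is therefore expected in this assay for this change. The estimated step is a 1.1-fold lower number from compound 3 to compound 4 (0.02 log units; within the scatter) on this evidence. Compound 4 is estimated at 12000 nM with an expected range of 4000 nM to 32000 nM in this measurement.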

Compound 4, concentration for 50% growth inhibition: > 10000 nM
Compound 4: a limit, no number; the forecaster's own chance of this, stated with the estimate: 10%; the middle value does not contradict the limit.
By their numbers in this assay, from the lowest: compound 1; then compound 3; then compound 2.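

In this assay compound 4 gives > 10000 nM, which is a limit and not a number, so the steps to compound 4 from compound 2 and compound 3 cannot be read. The compounds shown leave open how 4-(dimethylamino)phenyl on a carbonyl carbon compares with 3-nitrophenyl or pyrazin-2-yl there.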